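The source may report more compounds than this note shows. Statements on the series, on what has been measured and on what is new or still open speak of the compounds shown alone.

Series notes. The shared core of compound 1 `O=C1C[C@H](O)C[C@@H](/C=C/c2ccccc2-c2ccccc2)O1` is carried through compound 2 `Cc1cc(F)ccc1-c1cc(Cl)cc(Cl)c1/C=C/[C@@H]1C[C@@H](O)CC(=O)O1` and compound 3 `O=C1C[C@H](O)C[C@@H](/C=C/c2c(Cl)cc(Cl)cc2-c2ccccc2)O1`. In an assay for inhibition of 3-hydroxy-3-methylglutaryl-coenzyme A reductase (Rattus norvegicus) (a lower number here means a stronger inhibitor, a higher number a weaker inhibitor), compound 1 gives 3000 nM, compound 2 gives 36 nM and compound 3 gives 80 nM. Compound 3 therefore stands second of the three numbers in this assay: its nearest neighbour is compound 2, and its furthest is compound 1, whose value set against that of compound 3 shows a wide separation.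

Compound 4 `O=C1C[C@H](O)C[C@@H](/C=C/c2c(Cl)cc(Cl)cc2CCc2ccccc2)O1` is the next step: phenethyl in place of phenyl on an aromatic carbon. For the measured compounds named here, the change sits on the same aromatic carbon that varied between compound 2 and compound 3, so that pair is the only measured step bearing on it; it exchanged phenyl for 4-fluoro-2-methylphenyl, whereas here a phenethyl group enters in place of phenyl, a change that no measured pair tests directly. Because the step from compound 2 to compound 3 was only a 2.2-fold higher number from compound 2 to compound 3 (0.35 log units; beyond the scatter), a step of at most moderate size is expected here, most likely toward a higher number, with wide uncertainty. Compound 4 is expected to give 200 nM in this assay, within 50 nM to 800 nM. The expected step from compound 3 to compound 4 is accordingly a 2.5-fold higher number from compound 3 to compound 4 (0.40 log units; beyond the scatter).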

Compound 4, half-maximal inhibitory concentration: 430 nM
Compound 4: middle estimate off by 2.2-fold (0.33 log units), on the low side, and the stated range covers the measured number.
By their numbers in this assay, from the lowest: compound 2; then compound 3; then compound 4; then compound 1.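

Phenethyl is tolerated on this aromatic carbon in this assay, but the position responds to more than the substituents on the attached ring: the enter-and-leave groups each hold one six-membered aromatic ring of carbon only and neither has hydrogen-bond donors or acceptors, yet the exchange of phenyl for phenethyl gives a 5.4-fold higher number from compound 3 to compound 4 (0.73 log units; beyond the scatter). Set against the 4-fluoro-2-methylphenyl group, phenethyl gives a 12-fold higher number from compound 2 to compound 4 (1.08 log units; beyond the scatter), so this change moves the number considerably further than the earlier aryl exchange at the same carbon suggested, and both new steps run in the same direction, toward a weaker inhibitor. No measurement on these compounds accounts for the shift.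

Open, going by these compounds, is whether the loss follows the length of the chain or the mere presence of a link, which a benzyl group or a longer phenylpropyl chain on the same aromatic carbon would help to separate. Also open, on these data alone, is whether 4-fluoro-2-methyl substitution on the phenethyl ring, or an amine or a carboxylic acid at the end of the chain, would change the number in either direction.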